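From bromo to trifluoromethyl on the shared core

The source may hold more compounds than are shown below. What is called first, only, known or untested is meant among the compounds shown, and "the series" means these compounds.

Measured in a functional assay on HCT-116 cells (Homo sapiens) for antiproliferative activity, read by MTT assay, with a stated time of 48 h; on this read-out higher numbers stand for weaker inhibition of growth and lower numbers for stronger inhibition of growth:
Compound 1 `Fc1ccc(C2=NN(C(=S)Nc3ccccc3)C(c3ccc4c(c3)OCCO4)C2)cc1`: 61200 nM
Compound 2 `S=C(Nc1ccccc1)N1N=C(c2ccc(Cl)cc2)CC1c1ccc2c(c1)OCCO2`: > 200000 nM (a limit of the assay, not a number)
Compound 3 `S=C(Nc1ccccc1)N1N=C(c2ccc(Br)cc2)CC1c1ccc2c(c1)OCCO2`: 32100 nM

Compound 3 stands at 32100 nM and compound 1 at 61200 nM, so the two sit together, with a 1.9-fold lower number from compound 1 to compound 3 (0.28 log units; within the scatter). Compound 2 gives only a limit. The two steps that involve it, an at least 3.2-fold higher number from compound 1 to compound 2 (0.51 log units; beyond the scatter) and an at least 6.2-fold lower number from compound 2 to compound 3 (0.79 log units; beyond the scatter), are both beyond the scatter, and compound 2 goes against any steady trend among the halogens.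

Compound 4 `FC(F)(F)c1ccc(C2=NN(C(=S)Nc3ccccc3)C(c3ccc4c(c3)OCCO4)C2)cc1` carries trifluoromethyl in place of bromo on an aromatic carbon, para to a large group (trifluoromethyl in place of bromo on an aromatic carbon). Among the measured compounds shown here, no measured step makes this exact change, so the halogen swaps are the only guide. For the measured compounds named here, the one swap between two true numbers stayed within the scatter, while the swaps involving compound 2 warn of a possible larger move. No step beyond the scatter is therefore expected in this assay, and the expected step is a 1.2-fold higher number from compound 3 to compound 4 (0.10 log units; within the scatter). For compound 4 the estimated value is 40000 nM, with an expected range from 12000 nM to 130000 nM.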

Compound 4, concentration for 50% growth inhibition: 112000 nM
For compound 4 the middle estimate is 2.8-fold (0.45 log units) below the measured one, within the range that was stated.
By their numbers in this assay, from the lowest: compounds 3, 1 and 4 (each within the scatter of the next, the first and the last beyond it). At a limit, above all of these: compound 2.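

In this assay, among the compounds shown here, the change from 4-bromophenyl to 4-(trifluoromethyl)phenyl gives a clear separation (a 3.5-fold higher number from compound 3 to compound 4 (0.54 log units; beyond the scatter)), the only swap at this position between two true numbers that lies beyond the scatter. Trifluoromethyl in place of fluoro stays within the scatter (a 1.8-fold higher number from compound 1 to compound 4 (0.26 log units; within the scatter)), and so does bromo in place of fluoro (a 1.9-fold lower number from compound 1 to compound 3 (0.28 log units; within the scatter)), although compound 3 and compound 4 lie beyond it from each other. Trifluoromethyl in place of chloro gives only a floor (an at least 1.7-fold lower number from compound 2 to compound 4 (0.25 log units; that floor lies within the scatter)). The true size of this step cannot be read because compound 2 stands at a limit of the assay, not at a number: (the limit of > 200000 nM in this assay, at which 1 of the 4 values shown sits).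

On these data alone, it remains open whether a methoxy group, an amine or a carboxylic acid at this position would fall in the same range. Also open, as far as these compounds go, is whether the separation between bromo and trifluoromethyl would hold with a different group in place of the phenyl on the thioamide nitrogen.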